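Moving the Methyl Group on the Benzyl Ring

A few compounds are considered here, and "the series" means these few. Any claim that something is new, unique, unknown or untested is made for them only; others in the source may bear on it.

Of the compounds shown here, two have been measured in an assay on isolated protein for inhibition of Long-chain-fatty-acid--CoA ligase 1 (Mus musculus), read by mass spectrometry, with a stated time of 90 min, in the presence of a further agent that is not named here; on this read-out lower numbers stand for stronger inhibition and higher numbers for weaker inhibition. Compound 1 `Cc1cccc(Cc2nc3cc(O[C@H]4CC[C@@H](C(=O)O)CC4)ccc3n2C)c1` gives 30 nM, the lower of the two numbers. Compound 2 `Cc1cccc(Cc2c(C#N)c3cc(O[C@H]4CC[C@@H](C(=O)O)CC4)ccc3n2C)c1` differs from compound 1 in its core; in this assay compound 2 gives 600 nM, a clearly higher number. Compound 3 `Cc1ccccc1Cc1nc2cc(O[C@H]3CC[C@@H](C(=O)O)CC3)ccc2n1C` has not yet been measured. It holds the same atoms as compound 1, joined differently: 2-methylphenyl in place of 3-methylphenyl on a saturated chain carbon bound to an aromatic carbon. Among the compounds with values here, no measured pair in this set shows what shifting the methyl group around this ring does, so the size of the step is uncertain. The expectation is a modest change, most likely a somewhat higher number than compound 1, although a result within the usual scatter would not be surprising. Compound 3 is therefore estimated at 60 nM, with a plausible range from 15 nM to 250 nM. That estimate corresponds to an expected step of a 2.0-fold higher number from compound 1 to compound 3 (0.30 log units; within the scatter).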

Compound 3, half-maximal inhibitory concentration: 5400 nM
The estimate for compound 3 lay 90-fold (1.95 log units) below the measured number, outside the stated range (above it).
By their numbers in this assay, from the lowest: compound 1; then compound 2; then compound 3.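

In this assay, within the data shown here, shifting the single methyl group from 3-methylphenyl to 2-methylphenyl gives a 180-fold higher number from compound 1 to compound 3 (2.26 log units; beyond the scatter), even though the two groups hold the same atoms and the same ring. This shows that the group on the saturated chain carbon bound to an aromatic carbon is highly sensitive to where its methyl sits: the placement of one carbon alone produces a large step in this series. Nothing measured here explains why the number rises so far. The compounds shown leave open whether the methyl group helps at all, as plain phenyl with no methyl is not among them. They also leave open how a methoxy group or a chlorine atom would read in place of the methyl of compound 1.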